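From a difluorocyclohexyl to a methylpropenyl on the pyridine ring

The source may report more compounds than this note shows. Statements on the series, on what has been measured and on what is new or still open speak of the compounds shown alone.

Three compounds in this series share one core and differ only in the group carried on the aromatic carbon of the six-membered ring with one nitrogen. Compound 1 `CCCc1nc(C(F)(F)F)ccc1CNC(=O)C(C)c1ccc(NS(C)(=O)=O)c(F)c1` carries a propyl there, compound 2 `CCCCCCc1nc(C(F)(F)F)ccc1CNC(=O)C(C)c1ccc(NS(C)(=O)=O)c(F)c1` a hexyl, and compound 3 `CC(C(=O)NCc1ccc(C(F)(F)F)nc1C1CCC(F)(F)CC1)c1ccc(NS(C)(=O)=O)c(F)c1` a 4,4-difluorocyclohexyl. In an assay on CHO cells for antagonist activity at transient receptor potential cation channel subfamily V member 1 (Homo sapiens), read by FLIPR and calcium flux (a lower number here means a stronger inhibitor, a higher number a weaker inhibitor), compound 1 gives 22.7 nM, compound 2 gives 1.6 nM, and compound 3 gives 1.5 nM, the lowest of the three numbers, with a 1.1-fold lower number from compound 2 to compound 3 (0.03 log units; within the scatter) and a 15-fold lower number from compound 1 to compound 3 (1.18 log units; beyond the scatter).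

Compound 4 `CC(C)=Cc1nc(C(F)(F)F)ccc1CNC(=O)C(C)c1ccc(NS(C)(=O)=O)c(F)c1` has not yet been measured. Its change from compound 3 is 2-methylprop-1-en-1-yl in place of 4,4-difluorocyclohexyl on an aromatic carbon. Among the measured compounds shown here, the steps that bear on this are the large one, a 15-fold lower number from compound 1 to compound 3 (1.18 log units; beyond the scatter), where a small chain was replaced by the ring, and the flat one, a 1.1-fold lower number from compound 2 to compound 3 (0.03 log units; within the scatter). Compound 4 moves back toward a small group of four heavy atoms, so a rise in the number toward that of compound 1 is expected, though the entering group is larger than propyl and an unsaturated one, so the full reversal need not appear.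

Compound 4 is therefore expected to show a 6.7-fold higher number from compound 3 to compound 4 (0.82 log units; beyond the scatter) in this assay, with an estimated value of 10 nM and a range from 3 nM to 40 nM.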

Compound 4, inhibition constant: 11.5 nM
For compound 4 the middle estimate is 1.2-fold (0.06 log units) below the measured one; the range from low to high includes it.
By their numbers in this assay, from the lowest: compounds 3 and 2 (each within the scatter of the next); then compounds 4 and 1 (each within the scatter of the next).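

In this assay, the 2-methylprop-1-en-1-yl group does not keep the level reached with the two larger groups at this position, next to the ring nitrogen: the result is a 7.7-fold higher number from compound 3 to compound 4 (0.88 log units; beyond the scatter) against the 4,4-difluorocyclohexyl and a 7.2-fold higher number from compound 2 to compound 4 (0.86 log units; beyond the scatter) against the hexyl. Against the propyl the result is a 2.0-fold lower number from compound 1 to compound 4 (0.30 log units; within the scatter), so exchanging that chain for a branched group with a double bond outside aromatic rings gives no change that can be separated from the scatter. The four compounds therefore fall into two pairs, compounds 2 and 3 with hexyl and 4,4-difluorocyclohexyl and compounds 1 and 4 with propyl and 2-methylprop-1-en-1-yl, and no measurement at hand accounts for this division.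

The compounds shown leave open whether the double bond of compound 4 matters at all, a question that a saturated 2-methylpropyl group at the same carbon would address. They also leave open whether the two fluorines of compound 3 contribute, as a plain cyclohexyl would show, and how a smaller ring such as cyclopropyl or a cyclic amine such as morpholine would compare there.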